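This account rests on a few compounds, and the source may have more. Where it says the series, first, only, none or still open, it means among the compounds named here.

Measured in a functional assay on HCT-116 cells (Homo sapiens) for cytotoxicity, read by MTT assay; on this read-out higher numbers stand for weaker inhibition and lower numbers for stronger inhibition:
- compound 1 `Nc1ccccc1NC(=O)c1ccc(CNc2ncccn2)cc1`: 2000 nM
- compound 2 `Nc1nc(NCc2ccc(C(=O)Nc3ccccc3N)cc2)c2nc[nH]c2n1`: 10000 nM

Compound 2 has the higher of the two numbers, and its gap down to compound 1 lies beyond the usual scatter. Not yet measured is compound 3 `CCCCn1cnc2c(NCc3ccc(C(=O)Nc4ccccc4N)cc3)nc(N)nc21`, which carries butyl in place of hydrogen on an aromatic nitrogen of the core of compound 2 (butyl in place of hydrogen on an aromatic nitrogen).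

Within the data shown here, the series holds no measured example of this change, so any expected step in this assay is a judgement with wide uncertainty. A moderate step toward a lower number is expected, possibly not beyond the scatter, as compound 2 at 10000 nM sits at the top of the measured values. The expected move is a 2.5-fold lower number from compound 2 to compound 3 (0.40 log units; beyond the scatter). The estimate for compound 3 is 4000 nM, with an expected range from 1000 nM to 15000 nM.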

Compound 3, half-maximal inhibitory concentration: 2000 nM
For compound 3 the middle estimate is 2.0-fold (0.30 log units) above the measured one; low and high end bracket the measured number.
By their numbers in this assay, from the lowest: compounds 1 and 3 (each within the scatter of the next); then compound 2.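

In this assay, among these compounds, the aromatic nitrogen of the five-membered ring in the core of compound 2 accepts substitution: butyl in place of hydrogen gives a 5.0-fold lower number from compound 2 to compound 3 (0.70 log units; beyond the scatter) as the only measured change at this position. A hydrogen on this nitrogen is therefore not required for the read-out, and a four-carbon chain without a ring is accepted there. This rests on a single pair, and no available data explain the step.

Going by these compounds, it remains open whether the lower number depends on the length of the chain or only on replacing the hydrogen, which methyl and hexyl on the same nitrogen would help to separate. Also open, on these data alone, is how the position responds to a chain ending in an amine or a carboxylic acid, or to a benzyl group.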